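Bromo to chloro on the chain of compound 3

This account rests on a few compounds, and the source may have more. Where it says the series, first, only, none or still open, it means among the compounds named here.

In a functional assay on L1210 cells (Mus musculus) for inhibition (on this read-out lower numbers stand for stronger inhibition and higher numbers for weaker inhibition), compound 1 `C/C=C/c1cc(=O)[nH]c(=O)n1C1O[C@H](CO)[C@@H](O)[C@H]1O` gives > 35000 nM, which is a limit of the assay and not a number. Compound 2 `C=Cc1nc(O)nc(O)c1Cl` gives 4500 nM, and compound 3 `CCOC(=O)/C(Br)=C\c1cc(O)nc(O)n1` gives the lower number, 1000 nM, with the gap between the two beyond the scatter. Compound 3 therefore stands lowest among the numbers available.

Compound 4 `CCOC(=O)/C(Cl)=C\c1cc(O)nc(O)n1` has chloro in place of bromo on a double-bonded chain carbon bound to a carbonyl carbon and a double-bonded chain carbon. For the measured compounds named here, no measured pair shows this exchange. No step beyond the scatter is expected in this assay, with a slight lean toward a higher number. The estimated move is a 1.4-fold higher number from compound 3 to compound 4 (0.15 log units; within the scatter). For compound 4 the estimate is 1400 nM, with an expected range of 500 nM to 4000 nM.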

Compound 4, half-maximal inhibitory concentration: 3000 nM
Beside the measured number, compound 4's estimate is 2.1-fold (0.33 log units) below it; low and high end bracket the measured number.
By their numbers in this assay, from the lowest: compound 3; then compounds 4 and 2 (each within the scatter of the next). At a limit, above all of these: compound 1.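

Working at one place for the first time, chloro in place of bromo on a double-bonded chain carbon bound to a carbonyl carbon and a double-bonded chain carbon gives a 3.0-fold higher number from compound 3 to compound 4 (0.48 log units; beyond the scatter) in this assay. The halogen at this place therefore matters, though modestly, and bromo gives the lower number of the two. Nothing measured among the compounds shown accounts for this step.

As far as these compounds go, whether iodo or fluoro at this place would extend the order stays open. So does what a carboxylic acid or an amide would do in place of the ethyl ester.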